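The source may report more compounds than this note shows. Statements on the series, on what has been measured and on what is new or still open speak of the compounds shown alone.

In a physicochemical assay for solubility, with a stated time of 24 h, tested at 30 mg/mL (on this read-out lower numbers stand for lower solubility and higher numbers for higher solubility), compound 2 (`O=C(CCCCCNc1c(NCc2ccccc2)c(=O)c1=O)NO`) gives 5700000 nM and stands second highest of three numbers, with compound 1 (`O=C(CCCCCNc1c(Nc2ccccc2)c(=O)c1=O)NO`) at 2200000 nM and compound 3 (`CC[C@H](Nc1c(NCCCCCC(=O)NO)c(=O)c1=O)c1ccccc1`) at 57000000 nM on either side. Compound 4 (`O=C(CCCCCNc1c(NC2CCCCC2)c(=O)c1=O)NO`) carries cyclohexyl in place of benzyl on a nitrogen on an aromatic ring. Two measured steps come nearest: benzyl in place of phenyl gave a 2.6-fold higher number from compound 1 to compound 2 (0.41 log units; beyond the scatter) and ethyl in place of hydrogen gave a 10-fold higher number from compound 2 to compound 3 (1.00 log units; beyond the scatter) and both were modest. Neither replaces an aromatic ring with a non-aromatic one, so they give no direction, and no step beyond the scatter is expected in this assay for this change. The estimate means a 1.2-fold higher number from compound 2 to compound 4 (0.09 log units; within the scatter) (an expected step, not a measured one). For compound 4 the estimated value is 7000000 nM (expected range 2500000 nM to 20000000 nM).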

Compound 4, solubility: 8700000 nM
Compound 4: the middle estimate sits 1.2-fold (0.09 log units) below what was measured; the range from low to high includes it.
By their numbers in this assay, from the lowest: compound 1; then compounds 2 and 4 (each within the scatter of the next); then compound 3.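

In this assay, cyclohexyl in place of benzyl on this nitrogen gives a 1.5-fold higher number from compound 2 to compound 4 (0.18 log units; within the scatter), so at this position the non-aromatic ring and the benzyl group cannot be told apart. Cyclohexyl in place of phenyl gives a 4.0-fold higher number from compound 1 to compound 4 (0.60 log units; beyond the scatter), which leaves phenyl set apart from cyclohexyl as it was from benzyl. No supporting measurement bears on what lies behind this result. From the compounds shown here alone, it remains open whether cyclohexyl would keep pace with benzyl if either ring carried an amine or a carboxylic acid, or if a longer chain joined the ring to the nitrogen.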